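Aryl-hydrazone urea series: a hydroxyphenyl variant of compound 1

This account rests on a few compounds, and the source may have more. Where it says the series, first, only, none or still open, it means among the compounds named here.

Measured so far:
compound 1 `COc1ccc(/C=N/NC(=O)Nc2ccc(Oc3ccnc(-c4nncn4CCN(C)C)c3)c(F)c2)c(OC)c1OC`: 3970 nM
compound 2 `CN(C)CCn1cnnc1-c1cc(Oc2ccc(NC(=O)N/N=C/c3ccc(F)cc3)cc2F)ccn1`: 1370 nM
compound 3 `COc1cc(/C=N/NC(=O)Nc2ccc(Oc3ccnc(-c4nncn4CCN(C)C)c3)c(F)c2)ccc1O`: 120 nM

In a functional assay on HT-29 cells (Homo sapiens) for cytotoxicity, read by MTT assay, with a stated time of 72 h (a higher number here means a weaker inhibitor, a lower number a stronger inhibitor), compound 1 gives the highest of the three numbers; compound 2 is nearest with a 2.9-fold lower number from compound 1 to compound 2 (0.46 log units; beyond the scatter) and compound 3 furthest with a 33-fold lower number from compound 1 to compound 3 (1.52 log units; beyond the scatter). Compound 4 `Cc1cc(/C=N/NC(=O)Nc2ccc(Oc3ccnc(-c4nncn4CCN(C)C)c3)c(F)c2)cc(C)c1O` differs from compound 1 in one place: 4-hydroxy-3,5-dimethylphenyl in place of 2,3,4-trimethoxyphenyl on a carbon with a double bond to nitrogen. The step bearing on it most directly is a 33-fold lower number from compound 1 to compound 3 (1.52 log units; beyond the scatter), in which a 4-hydroxy-3-methoxyphenyl entered at the same carbon; an 11-fold lower number from compound 2 to compound 3 (1.06 log units; beyond the scatter) points the same way. The group entering in compound 4 is also a 4-hydroxyphenyl bearing ring substituents, so a large step downward is expected for compound 4, a 16-fold lower number from compound 1 to compound 4 (1.20 log units; beyond the scatter), though not necessarily as far as compound 3. Compound 4 is estimated at 250 nM, within 70 nM to 900 nM.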

Compound 4, half-maximal inhibitory concentration: 1220 nM
For compound 4 the middle estimate is 4.9-fold (0.69 log units) below the measured one; measured number outside the range, above it.
By their numbers in this assay, from the lowest: compound 3; then compounds 4 and 2 (each within the scatter of the next); then compound 1.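

A hydroxyl on the ring does not by itself carry the gain at this carbon in this assay: 4-hydroxy-3,5-dimethylphenyl gives only a 3.3-fold lower number from compound 1 to compound 4 (0.51 log units; beyond the scatter), whereas the change from 4-hydroxy-3-methoxyphenyl gives a 10-fold higher number from compound 3 to compound 4 (1.01 log units; beyond the scatter). Against 4-fluorophenyl, the same group gives a 1.1-fold lower number from compound 2 to compound 4 (0.05 log units; within the scatter), so a hydroxyl-bearing ring need not separate from a fluorinated one. No measurement shown accounts for the difference between the two hydroxyl-bearing rings.

Still open, going by these compounds, is whether the gain in compound 3 needs both the hydroxyl and the methoxy group. A 4-amino-3-methoxyphenyl or a 3-methoxyphenyl at this carbon would test each part.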